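Swapping a Benzyl Group for a Thiourea

The source may hold more compounds than are shown below. What is called first, only, known or untested is meant among the compounds shown, and "the series" means these compounds.

Measured compounds:
- compound 1, `NC(=O)c1c(NC(=O)c2ccccc2Cl)sc2c1CCN(Cc1ccccc1Cl)C2`: 4430 nM
- compound 2, `NC(=O)c1c(NC(=O)c2cccc([N+](=O)[O-])c2)sc2c1CCN(Cc1c(Cl)cccc1Cl)C2`: 13500 nM

Both were tested in a functional assay on MKN-74 cells (Homo sapiens) for antiproliferative activity, with a stated time of 24 h; a higher number here means a weaker inhibitor, a lower number a stronger inhibitor. Compound 1 gives 4430 nM, the lower of the two numbers. Compound 2, which carries a nitrobenzoyl amide and a 2,6-dichlorobenzyl group on the shared core, gives 13500 nM, a gap that lies beyond the scatter of this assay.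

Compound 3, `NC(=O)c1c(NC(=O)c2ccccc2Cl)sc2c1CCN(C(=S)Nc1ccccc1)C2`, keeps the chlorobenzoyl amide of compound 1 and changes only one part: a group of 9 heavy atoms (7 carbon, 1 nitrogen, 1 sulfur; one six-membered aromatic ring of carbon only) in place of a group of 8 heavy atoms (7 carbon, 1 chlorine; one six-membered aromatic ring of carbon only), on an amine nitrogen in a ring. In words, the 2-chlorobenzyl group on the ring amine nitrogen is replaced by a thiourea bearing a phenyl group. Within the data shown here, no pair of measured compounds shows this kind of change, so nothing measured here anchors its effect. The expected step from compound 1 to compound 3 in this assay is a 1.5-fold higher number from compound 1 to compound 3 (0.17 log units; within the scatter), small and within or only slightly beyond the scatter, leaning toward a weaker inhibitor. Compound 3 is estimated at 6500 nM, with a range from 1500 nM to 28000 nM.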

Compound 3, half-maximal inhibitory concentration: 15600 nM
Compound 3: middle estimate off by 2.4-fold (0.38 log units), on the low side; the range from low to high includes it.
By their numbers in this assay, from the lowest: compound 1; then compounds 2 and 3 (each within the scatter of the next).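

On the amine nitrogen in the ring, replacing the 2-chlorobenzyl group with a thiourea bearing a phenyl group gives a 3.5-fold higher number from compound 1 to compound 3 (0.55 log units; beyond the scatter) in this assay and so shows that this position responds to the group it carries. Groups of 8 and 9 heavy atoms, each with one six-membered aromatic ring of carbon only, are therefore not interchangeable here. The entering group also adds a hydrogen-bond donor, a hydrogen-bond acceptor and a double bond outside aromatic rings, but no measurement shown separates these differences or explains the step.

From the compounds shown here alone, it remains open whether the thiourea link or its phenyl group accounts for the step. A urea, with oxygen in place of the sulfur, or a thiourea bearing an ethyl chain instead of the phenyl group could help separate the two.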